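Swapping a para bromine for fluorine on the sulfonyl aryl

This account rests on a few compounds, and the source may have more. Where it says the series, first, only, none or still open, it means among the compounds named here.

Measured so far:
Compound 1, `O=S(=O)(NCCCNc1nccc(-c2c(-c3cccc(F)c3)nc3sccn23)n1)c1cccc(F)c1`: 13700 nM
Compound 2, `O=S(=O)(NCCCNc1nccc(-c2c(-c3cccc(F)c3)nc3sccn23)n1)c1ccc(Br)cc1`: 7040 nM

In a functional assay on A-375 cells (Homo sapiens) for cytotoxicity, read by MTT assay (on this read-out higher numbers stand for weaker inhibition and lower numbers for stronger inhibition), compound 2 gives the lowest of the two numbers, with compound 1 nearest; the gap a 1.9-fold lower number from compound 1 to compound 2 (0.29 log units; within the scatter) does not rise above the usual scatter, so the two compounds cannot be told apart. Compound 3, `O=S(=O)(NCCCNc1nccc(-c2c(-c3cccc(F)c3)nc3sccn23)n1)c1ccc(F)cc1`, is not yet measured. Its change from compound 2 is fluoro in place of bromo on an aromatic carbon, on a para position of the sulfonyl-bound ring. For the measured compounds named here, no measured step changes bromo to fluoro at a fixed place; the only step available, a 1.9-fold lower number from compound 1 to compound 2 (0.29 log units; within the scatter), alters both the halogen and its position at once and so bears only loosely on compound 3. With no step beyond the scatter to build on, compound 3 is expected to land close to compound 2, the step of a 1.4-fold higher number from compound 2 to compound 3 (0.15 log units; within the scatter) being an estimate that stays within the scatter. The estimate for compound 3 is 10000 nM, between 3500 nM and 28000 nM.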

Compound 3, half-maximal inhibitory concentration: 14500 nM
Beside the measured number, compound 3's estimate is 1.5-fold (0.16 log units) below it; measured number inside the range.
By their numbers in this assay, from the lowest: compounds 2, 1 and 3 (each within the scatter of the next, the first and the last beyond it).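

For the compounds shown here, with the place on the ring held fixed, fluoro in place of bromo gives a 2.1-fold higher number from compound 2 to compound 3 (0.31 log units; beyond the scatter), the first measured change of the halogen alone, and a modest one that only just clears the usual scatter. Moving the fluorine, with 4-fluorophenyl in place of 3-fluorophenyl on the sulfonyl sulfur, gives a 1.1-fold higher number from compound 1 to compound 3 (0.02 log units; within the scatter), so in this assay these two placements of fluorine cannot be told apart. Nothing available here explains why compound 2 gives the lower number.

As far as these compounds go, only bromo and fluoro appear on this ring, so it remains open how a chloro, methoxy or amino group would read in the same place. A 3-bromophenyl group would show whether the place on the ring matters for bromine, and plain phenyl would show what either halogen adds.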